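Dichloro Step on a Purine-like Core, Cytotoxicity on Ovarian Cells

The source may report more compounds than this note shows. Statements on the series, on what has been measured and on what is new or still open speak of the compounds shown alone.

Measured compounds:
compound 1, `ClCc1cccc(Cn2cnc3ncnc(Cl)c32)c1`: 60300 nM
compound 2, `ClCc1cccc(Cn2cnc3c(Cl)ncnc32)c1`: 79400 nM
compound 3, `ClCc1cccc(Cn2cnc3c(Cl)nc(Cl)nc32)c1`: 67600 nM

These three were tested in a functional assay on OVCAR-8 cells (Homo sapiens) for cytotoxicity, read by sulforhodamine B assay, with a stated time of 48 h; on this read-out lower numbers stand for higher toxicity in this test and higher numbers for lower toxicity in this test. In this assay compound 1 gives 60300 nM, compound 2 gives 79400 nM and compound 3 gives 67600 nM; all three lie within the scatter of one another. Compound 1 and compound 2 share the same atoms joined differently, and the difference between the two cores is not broken down here. From compound 2 to compound 3 the change is chloro in place of hydrogen on an aromatic carbon, and it made a 1.2-fold lower number from compound 2 to compound 3 (0.07 log units; within the scatter).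

Compound 4, `ClCc1cccc(Cn2cnc3nc(Cl)nc(Cl)c32)c1`, is not yet measured. It differs from compound 1 by chloro in place of hydrogen on an aromatic carbon, the same change as from compound 2 to compound 3. Because that step was a 1.2-fold lower number from compound 2 to compound 3 (0.07 log units; within the scatter), the expected step from compound 1 to compound 4 is a 1.0-fold lower number from compound 1 to compound 4 (0.00 log units; within the scatter). Compound 4 is therefore estimated at 60000 nM, with a likely range from 30000 nM to 120000 nM.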

Compound 4, concentration lethal to 50% of the cells: 45700 nM
Compound 4: the middle estimate sits 1.3-fold (0.12 log units) above what was measured; low and high end bracket the measured number.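

In this assay, chloro in place of hydrogen on an aromatic carbon of the core of compound 1 gave a 1.3-fold lower number from compound 1 to compound 4 (0.12 log units; within the scatter). Set beside the earlier step, the same change looks alike on the two cores, though neither step stands clear of the usual scatter: the same change on two cores in this assay, a 1.2-fold lower number (0.07 log units; within the scatter) from compound 2 to compound 3 and a 1.3-fold lower number (0.12 log units; within the scatter) from compound 1 to compound 4, 1.1-fold (0.05 log units) apart, within the scatter of two such steps. Among these compounds, this shows only that the change has no readable effect on either core in this test; it does not show that a real effect would carry from one core to the other, and two pairs are a small base.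

The compounds shown leave open whether an amine or a methoxy group in that same place would shift the number beyond the scatter. They also leave open whether either core would respond in the same way to such a group.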